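Swapping the Aryl Group on the Amide Nitrogen

A few compounds are considered here, and "the series" means these few. Any claim that something is new, unique, unknown or untested is made for them only; others in the source may bear on it.

Compound 3 `O=C(CN1CCC(c2cccc[n+]2[O-])CC1)Nc1ccc(F)cc1` carries a 4-fluorophenyl on an amide-type nitrogen. In a functional assay on HEK293 cells for agonist activity at D(4) dopamine receptor (Homo sapiens), read by FLIPR (on this read-out lower numbers stand for smaller maximal responses and higher numbers for larger maximal responses), compound 3 gives 71%, the highest of the three numbers measured, although compound 1 `CCc1cccc(NC(=O)CN2CCC(c3cccc[n+]3[O-])CC2)c1` with 62% and compound 2 `Cc1cc(Br)ccc1NC(=O)CN1CCC(c2cccc[n+]2[O-])CC1` with 61% both lie within the scatter of it: a number 9 percentage points higher from compound 1 to compound 3 (within the scatter) and a number 10 percentage points higher from compound 2 to compound 3 (within the scatter). Compound 4 `Cc1ccc(Cl)cc1NC(=O)CN1CCC(c2cccc[n+]2[O-])CC1` differs from compound 3 by 5-chloro-2-methylphenyl in place of 4-fluorophenyl on an amide-type nitrogen. The third exchange of this aryl group among the measured compounds likewise gave a number 1 percentage points lower from compound 1 to compound 2 (within the scatter), so no step beyond the scatter is expected here either. Compound 4 is therefore estimated at 65%, between 50% and 80%, which means an expected step of a number 6 percentage points lower from compound 3 to compound 4 (within the scatter).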

Compound 4, largest response reached (reported as efficacy), in percent of the reference or control that the assay uses: 58%
Beside the measured number, compound 4's estimate is 7 percentage points above it, within the range that was stated.
By their numbers in this assay, from the lowest: compounds 4, 2, 1 and 3 (each within the scatter of the next, the first and the last beyond it).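

Within the data shown here, this is the first exchange of the aryl group on the amide-type nitrogen to clear the scatter in this assay (a number 13 percentage points lower from compound 3 to compound 4 (beyond the scatter)), so this position can shift the maximal response, though only modestly. The other two exchanges stay within the scatter (a number 3 percentage points lower from compound 2 to compound 4 (within the scatter); a number 4 percentage points lower from compound 1 to compound 4 (within the scatter)), so only compound 3 and compound 4 are separated. Nothing available explains this step.

The compounds shown cannot separate the contribution of the chlorine from that of the methyl in 5-chloro-2-methylphenyl. Going by these compounds, how a cyclohexyl or a benzyl group would behave on this nitrogen also remains open.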